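This account rests on a few compounds, and the source may have more. Where it says the series, first, only, none or still open, it means among the compounds named here.

Compound 1 `NC[C@@H]1CCCc2cc(S(=O)(=O)c3cc[nH]c3)ccc21` and compound 2 `CN(C)S(=O)(=O)NC[C@@H]1CCCc2cc(S(=O)(=O)c3cccc(F)c3)ccc21` share a core carrying a sulfonyl-linked aryl group and an aminomethyl side chain. In an assay on isolated protein for displacement of a labelled ligand from 5-hydroxytryptamine receptor 6 (Homo sapiens) (on this read-out higher numbers stand for weaker inhibition and lower numbers for stronger inhibition), compound 1 gives 0.316 nM, while compound 2 gives 2 nM, the higher of the two numbers and beyond the usual scatter. Compound 3 `O=C(NC[C@@H]1CCCc2cc(S(=O)(=O)c3cccc(F)c3)ccc21)[C@H]1CCCN1` has not been measured. It differs from compound 2 by (pyrrolidin-2-yl)carbonyl in place of dimethylsulfamoyl on an amine nitrogen. Both compounds keep the chain nitrogen capped, so the step from compound 2 to compound 3 is expected to be small, a 1.3-fold lower number from compound 2 to compound 3 (0.10 log units; within the scatter), in no clear direction beyond the scatter. Compound 3 is therefore estimated at 1.6 nM, within 0.4 nM to 7 nM.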

Compound 3, inhibition constant: 0.631 nM
Compound 3: the middle estimate sits 2.5-fold (0.40 log units) above what was measured; low and high end bracket the measured number.
By their numbers in this assay, from the lowest: compounds 1 and 3 (each within the scatter of the next); then compound 2.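

The group capping this amine nitrogen does affect the result in this assay: with the rest of the molecule unchanged, (pyrrolidin-2-yl)carbonyl in place of dimethylsulfamoyl gives a 3.2-fold lower number from compound 2 to compound 3 (0.50 log units; beyond the scatter). The step is modest, but it shows that the two caps are not interchangeable at this position. No measurement shown explains the difference. Going by these compounds, it remains open whether the five-membered ring matters or the carbonyl alone suffices, which a simple acetyl cap would test. The opposite stereocentre in the (pyrrolidin-2-yl)carbonyl group is also untested here.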